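A few compounds are considered here, and "the series" means these few. Any claim that something is new, unique, unknown or untested is made for them only; others in the source may bear on it.

Measured in a toxicity assay on L3.6pl cells (Homo sapiens) for inhibition, read by ATP content, with a stated time of 72 h; a higher number here means a weaker inhibitor, a lower number a stronger inhibitor:
- Compound 1 `COc1ccc(C(=O)Nc2ccc(N3CCCN(c4ncccn4)CC3)cc2C(=O)O)cc1`: > 30000 nM, a limit of the assay
- Compound 2 `COc1ccc(C(=O)Nc2ccc(N3CCN(c4ccccc4Cl)CC3)cc2C(=O)O)cc1`: 125000 nM
- Compound 3 `COc1ccccc1C(=O)Nc1ccc(CN2CCN(c3ccccn3)CC2)cc1C(=O)O`: > 10000 nM, a limit of the assay

Within the data shown here, compound 2 stands at 125000 nM, the only actual number among the three. The other two results are limits, so compound 2 cannot be ranked against them.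

The next compound to be tested is compound 4 `CCOc1ccccc1N1CCN(c2ccc(NC(=O)c3ccc(OC)cc3)c(C(=O)O)c2)CC1`. It departs from compound 2 at a single place: ethoxy in place of chloro on an aromatic carbon. In words, it carries ethoxy in place of chloro on an aromatic carbon, ortho to a large group, so that 2-chlorophenyl becomes 2-ethoxyphenyl.

Among the measured compounds shown here, no measured pair in this small set differs in just one place, so the data offer no direct guide to the size of such a change. The expectation therefore rests on compound 2 at 125000 nM, with the remainder of the structure unchanged. In this assay, no shift beyond the usual scatter is expected, and the estimated 1.3-fold lower number from compound 2 to compound 4 (0.10 log units; within the scatter) has no firm direction. The assay may also return only a limit for this compound. For compound 4 the expected value is 100000 nM, with an estimated range of 40000 nM to 300000 nM.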

Compound 4, half-maximal inhibitory concentration: > 20000 nM
Compound 4 ended at the assay's limit; the forecaster's own chance of this, stated with the estimate: 50%; the middle value does not contradict the limit.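

In this assay compound 4 gives > 20000 nM, a limit of the assay and not a number. The step from compound 2 to compound 4 therefore cannot be read. The compounds shown leave open how far ethoxy in place of chloro on an aromatic carbon shifts this read-out, and in which direction.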